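One Trifluoromethyl Fewer: What Size of Shift to Expect

The source may hold more compounds than are shown below. What is called first, only, known or untested is meant among the compounds shown, and "the series" means these compounds.

Compound 1 `O=C(Nc1cccc(-n2cc(-c3ccncc3)c(-c3cc(O)cc(Cl)c3)n2)c1)Nc1ccc(Cl)c(Cl)c1`: 84%
Compound 2 `COc1cc(Cl)cc(-c2nn(-c3cccc(NC(=O)Nc4cc(C(F)(F)F)cc(C(F)(F)F)c4)c3)cc2-c2ccncc2)c1`: 87%

In a functional assay on Malme-3M cells (Homo sapiens) for inhibition, read by sulforhodamine B assay, with a stated time of 48 h, tested at 0.1 uM (a lower number here means a stronger effect, a higher number a weaker effect of the compound at the concentration tested), compound 1 gives 84% and compound 2 gives 87%. Compound 2 holds the higher of the two numbers, but its gap to compound 1 lies within the usual scatter of repeated measurements, so the two compounds cannot be put in any order of effect; both show only a weak effect at the concentration tested.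

Compound 3 `COc1cc(Cl)cc(-c2nn(-c3cccc(NC(=O)Nc4cccc(C(F)(F)F)c4)c3)cc2-c2ccncc2)c1` differs from compound 2 in a single place: hydrogen in place of trifluoromethyl on an aromatic carbon. The change sits on an aromatic carbon of a six-membered aromatic ring of carbon only, meta to a large group and meta to a trifluoromethyl group.

Among the measured compounds shown here, no pair of measured compounds shows this same change, so there is no direct guide to its size. Given that compound 2 already gives 87%, the step of a number 3 percentage points higher from compound 2 to compound 3 (within the scatter) is expected to be small, either none beyond the scatter or a slightly higher number. Compound 3 is therefore estimated at 90%, with a likely range from 78% to 102%.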

Compound 3, a percentage reported as activity, at one concentration (the size of the read-out at that concentration, not a potency): 50%
For compound 3 the middle estimate is 40 percentage points above the measured one; measured number outside the range, below it.
By their numbers in this assay, from the lowest: compound 3; then compounds 1 and 2 (each within the scatter of the next).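

Hydrogen in place of trifluoromethyl on this aromatic carbon gives a number 37 percentage points lower from compound 2 to compound 3 (beyond the scatter) in this assay, and a lower number here means a stronger effect. This single place on the ring, meta to a large group, can therefore move the read-out far, even though only one of the two trifluoromethyl groups of compound 2 has gone. Compound 1 and compound 2 differ in more than one place, so their numbers alone could not show this, and nothing measured here speaks to the reason for the step.

Still open, as far as these compounds go, is what the trifluoromethyl group that remains in compound 3 contributes. Also open, from the compounds shown here alone, is how the read-out would respond to another group at the emptied place, such as an amine or a carboxylic acid.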